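The compounds below may be only part of what the source reports. "The series", "measured", "known", "first", "only" and "open" are said of these compounds alone.

Among the measured compounds shown here, compound 2 `CC(C)c1onc(-c2c(Cl)cccc2Cl)c1COc1ccc(N(C)Cc2ccc(OCC(=O)O)cc2)c(C(F)(F)F)n1` is one of two compounds measured here. In a functional assay on HEK293 cells for agonist activity at Bile acid receptor (Homo sapiens), read by a luciferase reporter (a lower number here means a smaller maximal response, a higher number a larger maximal response), compound 2 gives 59%. The other, compound 1 `CC(C)c1onc(-c2c(Cl)cccc2Cl)c1COc1ccc(N(C)C(=O)c2cccc(C(=O)O)c2)c(C(F)(F)F)n1`, gives in this assay 55%, and the step of a number 4 percentage points higher from compound 1 to compound 2 (within the scatter) shows that the two numbers lie within the scatter of each other, so neither can be said to respond more strongly.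

Compound 3 `CC(C)c1onc(-c2c(Cl)cccc2Cl)c1COc1ccc(N(C)Cc2ccc(OCCO)cc2)c(C(F)(F)F)n1` differs from compound 2 by hydroxymethyl in place of carboxy on a saturated chain carbon bound to an oxygen on an aromatic ring. For the measured compounds named here, no measured step removes a carboxy group; the one step known, a number 4 percentage points higher from compound 1 to compound 2 (within the scatter), exchanged one carboxy-bearing group for another and changed nothing beyond the scatter. There is thus no basis in these data for expecting a large shift in either direction, and the estimate a number 4 percentage points lower from compound 2 to compound 3 (within the scatter) is a step within the scatter. For compound 3 in this assay a maximal response of about 55% is expected, between 35% and 75%.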

Compound 3, largest response reached (reported as efficacy), in percent of the reference or control that the assay uses: 59%
Estimate against measurement, compound 3: 4 percentage points below; low and high end bracket the measured number.
By their numbers in this assay, from the lowest: compounds 1, 2 and 3 (each within the scatter of the next).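

Swapping carboxy for hydroxymethyl on a saturated chain carbon bound to an oxygen on an aromatic ring gives no change at the digits printed from compound 2 to compound 3 (within the scatter) in this assay. The earlier step only exchanged one carboxy-bearing group for another, whereas here the carboxy group itself leaves and the maximal response stays within the scatter, so in this pair a carboxy group at this place is not required for a response of this size. The step of a number 4 percentage points higher from compound 1 to compound 3 (within the scatter) fits this reading, with 4-(2-hydroxyethoxy)benzyl on the nitrogen in place of (3-carboxyphenyl)carbonyl. Nothing given here explains why the response holds.

Going by these compounds, whether an amine or a longer chain ending in hydroxy at this place would keep the response remains open. A maximal response also does not tell what concentration is needed to reach it.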